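Taking one methoxy group off compound 2

The source may report more compounds than this note shows. Statements on the series, on what has been measured and on what is new or still open speak of the compounds shown alone.

Compound 1 `CCSC(=S)SCC(=O)c1ccccc1` has no methoxy group on its aromatic ring. In a functional assay on HeLa cells (Homo sapiens) for antiproliferative activity, read by resazurin assay (on this read-out higher numbers stand for weaker inhibition and lower numbers for stronger inhibition), compound 1 gives 5010 nM against the cells. Compound 2 `CCSC(=S)SCC(=O)c1ccc(OC)c(OC)c1` carries methoxy groups on that ring and gives 5010 nM in the same test, which places it level with compound 1 at the digits shown.

The next compound is compound 3 `CCSC(=S)SCC(=O)c1cccc(OC)c1` and it differs from compound 2 in one place: hydrogen in place of methoxy on an aromatic carbon with hydrogen in place of methoxy on an aromatic carbon. This carbon is ortho to a methoxy group, which compound 3 keeps.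

Within the data shown here, no measured pair here differs in just one place, so no direct step is available as a guide. Compound 2 with its methoxy groups sits at 5010 nM and compound 1 without any sits at 5010 nM so little movement is expected in this assay in either direction, and nothing beyond the usual scatter. The expected change a 1.0-fold lower number from compound 2 to compound 3 (0.00 log units; within the scatter) is therefore small. The estimate for compound 3 is 5000 nM with an expected range from 2200 nM to 11000 nM across repeated measurements.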

Compound 3, half-maximal inhibitory concentration: 5010 nM
Compound 3: the middle estimate sits 1.0-fold (0.00 log units) below what was measured; low and high end bracket the measured number.
By their numbers in this assay, from the lowest: compounds 1, 2 and 3 (each within the scatter of the next).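

Among these compounds, compound 3 gives the first comparisons here in which only one place changes, as it differs from each of the other two compounds by a single methoxy group. In this assay, hydrogen in place of methoxy on the aromatic carbon that is ortho to a methoxy group and para to a group of 9 heavy atoms gives one step (no change at the digits printed from compound 2 to compound 3 (within the scatter)), and methoxy in place of hydrogen on an aromatic carbon of compound 1 gives the other (no change at the digits printed from compound 1 to compound 3 (within the scatter)). Each single methoxy change therefore leaves the read-out where it was, and nothing measured here explains why.

As far as these compounds go, what stays open is whether a group other than methoxy on this aromatic carbon, such as a hydroxyl group, a fluorine atom or an amine, would shift the number beyond the usual scatter. From the compounds shown here alone, it is equally open whether a change elsewhere in the shared core, such as a longer chain in place of the ethyl group, would do so.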